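This account rests on a few compounds, and the source may have more. Where it says the series, first, only, none or still open, it means among the compounds named here.

Compound 1 `CCN(CC)C(=O)C1CCCN(c2nc3c(cc2[N+](=O)[O-])c(=O)c(C(=O)O)cn3C2CC2)C1`: > 136000 nM, a limit.
Compound 2 `CCN(CC)C(=O)C1CCCN(c2nc3c(cc2[N+](=O)[O-])c(=O)c(C(=O)O)cn3-c2ccc(F)cc2)C1`: > 122000 nM, a limit.

In an ADME assay on Vero cells (Chlorocebus sabaeus) for cytotoxicity, read by MTT assay, with a stated time of 72 h (on this read-out higher numbers stand for weaker inhibition and lower numbers for stronger inhibition), neither compound has yielded a number. Compound 2 stands at > 122000 nM, which is only a limit, as the limit of > 122000 nM in this assay, at which 1 of the 2 values shown sits, records. Compound 3 `CCN(CC)C(=O)C1CCCN(c2nc3c(cc2[N+](=O)[O-])c(=O)c(C(=O)O)cn3C(C)(C)C)C1` carries tert-butyl in place of 4-fluorophenyl on an aromatic nitrogen. Among the measured compounds shown here, the one measured step at this nitrogen is a step that the two limits leave unreadable from compound 1 to compound 2. Going by these compounds, its size cannot be read, so it offers no size to carry over, and its direction is unknown. No step beyond the scatter is therefore expected in this assay, and another limit is the likely report. The estimated change is a step that the limit leaves unreadable from compound 2 to compound 3. For compound 3 the expected value is 130000 nM, with an estimated range of 70000 nM to 180000 nM.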

Compound 3, half-maximal inhibitory concentration: > 131000 nM
Compound 3 was reported as a limit; the forecaster's own chance of this, stated with the estimate: 85%; middle value at least 1.0-fold (0.00 log units) from the limit.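

Compound 1, compound 2 and compound 3 all stand as limits in this assay, and the steps among them cannot be read. The compounds shown leave open whether the group on the aromatic nitrogen makes any difference to this read-out.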